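Azepane Chain Terminus Swapped for a Tertiary Alcohol

This account rests on a few compounds, and the source may have more. Where it says the series, first, only, none or still open, it means among the compounds named here.

Compound 2 `CCCCNc1nc(N)nc(C)c1CCCn1cccn1` carries a (1H-pyrazol-1-yl) ring at the end of a three-carbon chain on the shared core. In an assay on HEK293 cells for agonist activity at Toll-like receptor 8 (Homo sapiens), read by spectrophotometry (a lower number here means that less compound is needed, a higher number that more compound is needed for the effect), compound 2 gives 1050 nM, the highest of the three numbers recorded so far. Compound 1 `CCCCNc1nc(N)nc(C)c1CCCN1CCCCCC1` gives 178 nM and compound 3 `CCCCNc1nc(N)nc(C)c1CCCCc1ccccc1` gives 857 nM in this assay. The recorded steps are a 5.9-fold higher number from compound 1 to compound 2 (0.77 log units; beyond the scatter) and a 4.8-fold higher number from compound 1 to compound 3 (0.68 log units; beyond the scatter), while a 1.2-fold lower number from compound 2 to compound 3 (0.09 log units; within the scatter) is within the scatter, so the pyrazole and the benzyl terminus behave alike and both sit well behind the azepane of compound 1.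

Compound 4 `CCCCNc1nc(N)nc(C)c1CCC(C)(C)O` shortens the chain and removes the ring: 1-hydroxy-1-methylethyl in place of (1H-pyrazol-1-yl)methyl on a saturated chain carbon, two bonds along the chain from an aromatic carbon. Among the compounds with values here, no measured step bears on a hydroxyl at this position, and none on a change in chain length; the only steps available concern exchanges of a ring terminus at a fixed chain length. The two ring exchanges that were measured both left the ring-bearing compounds within scatter of one another, which gives no basis to expect a large swing in either direction, so the step is expected to be a 1.3-fold higher number from compound 2 to compound 4 (0.12 log units; within the scatter) in this assay. For compound 4 the estimated value in this assay is 1400 nM, with a range from 400 nM to 5000 nM.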

Compound 4, half-maximal effective concentration: 3140 nM
Estimate against measurement, compound 4: 2.2-fold (0.35 log units) below; the measured number falls inside the stated range.
By their numbers in this assay, from the lowest: compound 1; then compounds 3 and 2 (each within the scatter of the next); then compound 4.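

Within the data shown here, replacing (1H-pyrazol-1-yl)methyl with 1-hydroxy-1-methylethyl at this place gives a 3.0-fold higher number from compound 2 to compound 4 (0.48 log units; beyond the scatter) in this assay, so this exchange separates two termini, whereas the pyrazole and benzyl termini of the earlier compounds could not be told apart: a 1.2-fold lower number from compound 2 to compound 3 (0.09 log units; within the scatter). The earlier compounds shown here carry a ring at the chain end, and compound 4 adds the first terminus with no ring and the first hydroxyl, with the highest of the four printed numbers. No measurement on hand accounts for this step, and the size of the step is all that can be taken from it.

As far as these compounds go, the change removes the ring, brings in the hydroxyl and alters the chain in a single step, so the share of each remains open, and a 2-hydroxyethyl or a 3-hydroxypropyl terminus would begin to separate them. Also open, from the compounds shown here alone, is whether the lower number of compound 1, 178 nM, belongs to the azepane alone or extends to other amines at the chain end, such as piperidine or dimethylamine.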